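Alkoxy chain length and maximal response in one series

A few compounds are considered here, and "the series" means these few. Any claim that something is new, unique, unknown or untested is made for them only; others in the source may bear on it.

The measured compounds and their values in a functional assay on A9L-m1 cells with A9 (Mus musculus) as the target; on this read-out higher numbers stand for larger maximal responses and lower numbers for smaller maximal responses:
compound 1, `COc1nccnc1C1CN2CCC1CC2`, gives 1%
compound 2, `CCOc1nccnc1C1CN2CCC1CC2`, gives 1%
compound 3, `CCCCOc1nccnc1C1CN2CCC1CC2`, gives 15%

Compound 3 is the highest of the three in this assay, with its step from compound 1 described as a number 14 percentage points higher from compound 1 to compound 3 (beyond the scatter) and from compound 2 as a number 14 percentage points higher from compound 2 to compound 3 (beyond the scatter). The unmeasured compound 4, `CCCCCOc1nccnc1C1CN2CCC1CC2`, is the next member of the series.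

From compound 1 to compound 2 the change is methyl in place of hydrogen on a saturated chain carbon bound to an oxygen on an aromatic ring, and this gave no change at the digits printed from compound 1 to compound 2 (within the scatter). From compound 3 to compound 4 the change is methyl in place of hydrogen on a saturated chain carbon, four bonds along the chain from an oxygen on an aromatic ring. The two are the same kind of change, but not the same: in the first the new methyl sits on a saturated chain carbon bound to an oxygen on an aromatic ring, in the second on a saturated chain carbon four bonds along the chain from that oxygen. The cores of compound 1 and compound 3 differ by propyl in place of hydrogen on a saturated chain carbon bound to an oxygen on an aromatic ring.

For compound 4 in this assay a modest upward step is expected, a number 10 percentage points higher from compound 3 to compound 4 (within the scatter), somewhat larger than the earlier one, because compound 3 already stands at 15% after a number 14 percentage points higher from compound 1 to compound 3 (beyond the scatter) while the first methyl step gave only no change at the digits printed from compound 1 to compound 2 (within the scatter). Compound 4 is accordingly estimated at 25%, within 8% to 45%.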

Compound 4, largest response reached (reported as maximum), in percent of the reference or control that the assay uses: 32%
The estimate for compound 4 lay 7 percentage points below the measured number; the range from low to high includes it.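

In this assay the addition of a methyl at the end of the alkoxy chain did not carry over unchanged from one core to another: the same change on two cores in this assay, no change at the digits printed (within the scatter) from compound 1 to compound 2 and a number 17 percentage points higher (beyond the scatter) from compound 3 to compound 4, 17 percentage points apart, beyond the scatter of two such steps

The larger chain extensions on the two shorter cores likewise gave different results: the same change on two cores in this assay, a number 14 percentage points higher (beyond the scatter) from compound 1 to compound 3 and a number 31 percentage points higher (beyond the scatter) from compound 2 to compound 4, 17 percentage points apart, beyond the scatter of two such steps

The new steps are a number 17 percentage points higher from compound 3 to compound 4 (beyond the scatter) and, for the longer extensions, a number 31 percentage points higher from compound 2 to compound 4 (beyond the scatter) and a number 31 percentage points higher from compound 1 to compound 4 (beyond the scatter) so in this series the size of a step on one core did not fix its size on another, but these few pairs do not show why the steps differ or give a general rule linking chain length to maximal response.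

The compounds shown leave open whether the rise continues with a longer chain such as hexyl or levels off. They also leave open how a branched chain, or a chain ending in an amine or a carboxylic acid, would behave on the shared core.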